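The source may report more compounds than this note shows. Statements on the series, on what has been measured and on what is new or still open speak of the compounds shown alone.

Values in an ADME assay on MT4 cells (Homo sapiens) for cytotoxicity, read by MTT assay, with a stated time of 96 h; on this read-out lower numbers stand for higher toxicity in this test and higher numbers for lower toxicity in this test:
- compound 1 `O=[N+]([O-])c1ccc(-c2nc3cc(C(F)(F)F)ccc3[nH]2)cc1`: 6000 nM
- compound 2 `O=[N+]([O-])c1ccc(-c2nc3cc(Cl)c(Cl)cc3[nH]2)cc1`: 17000 nM
- compound 3 `Cn1c(-c2ccc([N+](=O)[O-])cc2)nc2cc(C(F)(F)F)ccc21`: >= 100000 nM

Compound 3 stands at the limit of >= 100000 nM in this assay, at which 1 of the 3 values shown sits, which is a limit and not a number. Compound 4 `O=[N+]([O-])c1ccc(-c2nc3cc(C(F)(F)F)ccc3n2C2CCCCC2)cc1` carries cyclohexyl in place of methyl on an aromatic nitrogen. For the measured compounds named here, one measured step bears on this nitrogen: an at least 16-fold higher number from compound 1 to compound 3 (1.22 log units; beyond the scatter), for methyl in place of hydrogen. Going by the values given here, that step is large, but it starts from hydrogen, and no measured compound carries a larger group there. Compound 3 sits at a limit, so only a move to lower numbers could be read. A lower number is expected in this assay, and the estimated step is an at least 1.6-fold lower number from compound 3 to compound 4 (0.22 log units; that floor lies within the scatter). For compound 4 the estimated value is 60000 nM, with an expected range of 15000 nM to 100000 nM.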

Compound 4, half-maximal cytotoxic concentration: 49000 nM
The estimate for compound 4 lay 1.2-fold (0.09 log units) above the measured number, and the stated range covers the measured number.
By their numbers in this assay, from the lowest: compound 1; then compound 2; then compound 4. At a limit, above all of these: compound 3.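

For the compounds shown here, the change from hydrogen to cyclohexyl on this aromatic nitrogen gives an 8.2-fold higher number from compound 1 to compound 4 (0.91 log units; beyond the scatter), the first step at this position that reads as a number and not a floor. Going from methyl to cyclohexyl gives an at least 2.0-fold lower number from compound 3 to compound 4 (0.30 log units; that floor lies within the scatter), so the size of this change stays unsettled. Compound 3 remains a limit and not a number: the limit of >= 100000 nM in this assay, at which 1 of the 4 values shown sits.

Open, from the compounds shown here alone, is how an ethyl, a benzyl or an aminoethyl group on this nitrogen would read. Also open, going by these compounds, is whether substitution at this nitrogen moves the number in the same direction on the core of compound 2.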